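This account rests on a few compounds, and the source may have more. Where it says the series, first, only, none or still open, it means among the compounds named here.

Measured compounds:
- Compound 1, `Cc1ccc(/C=C/C(=O)/C=C(O)/C=C/c2ccc(C)o2)o1`: > 25000 nM in this assay
- Compound 2, `COc1ccc(/C=C/C(=O)C(=Cc2cc(OC)c(OC)c(OC)c2)C(=O)/C=C/c2ccc(OC)c(OC)c2)cc1OC`: 230 nM
- Compound 3, `COc1cc(/C=C/C(=O)C(=Cc2ccc(OC)c(OC)c2)C(=O)/C=C/c2ccc(O)c(OC)c2)ccc1O`: 430 nM

These three compounds were tested in a functional assay on A549 cells (Homo sapiens) for inhibition, read by sulforhodamine B assay, with a stated time of 48 h; a lower number here means a stronger inhibitor of growth, a higher number a weaker inhibitor of growth. Compound 1 gives only a limit, > 25000 nM, not a number. Compound 2 gives 230 nM, and compound 3 gives 430 nM; these two numbers lie within the usual scatter of each other, so neither compound stands apart from the other, and compound 2 simply sits among the two numbers shown rather than above or below them.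

Compound 4, `COc1ccc(/C=C/C(=O)C(=CO)C(=O)/C=C/c2ccc(OC)c(OC)c2)cc1OC`, has not yet been measured. It differs from compound 2 in one place: hydroxy in place of 3,4,5-trimethoxyphenyl on a double-bonded chain carbon bound to a double-bonded chain carbon. The third aromatic ring is thus gone, and a hydroxy takes its place on the chain.

Within the data shown here, no measured pair of compounds differs in a single place, so the size of this step can only be estimated. The step from compound 2 to compound 4 is expected to go toward weaker growth inhibition, beyond the scatter, as a 35-fold higher number from compound 2 to compound 4 (1.54 log units; beyond the scatter). That expectation rests on compound 1, which has no third aromatic ring and reaches only the limit (the limit of > 25000 nM in this assay, at which 1 of the 3 values shown sits). Compound 4 is estimated at 8000 nM, with a likely range from 2000 nM to 25000 nM.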

Compound 4, concentration for 50% growth inhibition: > 25000 nM
Compound 4: a limit, no number (the forecaster's own chance of this, stated with the estimate: 20%); middle value at least 3.1-fold (0.49 log units) from the limit.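

Hydroxy in place of 3,4,5-trimethoxyphenyl on a double-bonded chain carbon bound to a double-bonded chain carbon gives the first comparison at a single place in this assay, and it reads as an at least 100-fold higher number from compound 2 to compound 4 (2.03 log units; beyond the scatter). Among these compounds, no earlier pair differed in one place only, so this is the first direct sign that growth inhibition depends heavily on what this position carries. Compound 4 gives a limit and not a number, so the step has a lower bound but no exact size: the limit of > 25000 nM in this assay, at which 2 of the 4 values shown sit.

The compounds shown leave open whether this position needs an aromatic ring at all, or whether an unsubstituted phenyl or a small group such as methyl would keep growth inhibition. On these data alone, how an amine or a carboxylic acid at this carbon would read also remains open.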